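The source may report more compounds than this note shows. Statements on the series, on what has been measured and on what is new or still open speak of the compounds shown alone.

Measured so far: compound 1 `C[C@H](Oc1cc2cc(C(N)=O)ccc2nc1N)c1cc(F)ccc1-n1cccn1` with 13 uL/min; compound 2 `C[C@H](Oc1cc2ccccc2nc1N)c1cc(F)ccc1-n1cccn1` with "not determined" (no result reported).

In an ADME assay on cells (Hepatocyte, Homo sapiens) for metabolic stability (a lower number here means slower removal, a higher number faster removal of the compound), compound 1 gives 13 uL/min, whereas compound 2 gives "not determined" (no result reported), so compound 2 stands without a number in this assay. Compound 3 `C[C@H](Oc1cc2cc(C#N)ccc2nc1N)c1cc(F)ccc1-n1cccn1` differs from compound 2 in one place: cyano in place of hydrogen on an aromatic carbon. For the measured compounds named here, since compound 2 has no number in this assay, no step from it can be set out, and no step beyond the scatter is expected to be claimable from this pair. Compound 3 is expected to give about 15 uL/min, in the range 6 uL/min to 40 uL/min, an estimate resting on compound 1 having given 13 uL/min in this assay.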

Compound 3, intrinsic clearance in a liver preparation (reported as CLH), per the amount of preparation that the assay uses: 40 uL/min
Estimate against measurement, compound 3: 2.7-fold (0.43 log units) below, within the range that was stated.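

In this assay, this position on the six-membered aromatic ring of carbon only proves to matter: cyano in place of carbamoyl gives a 3.1-fold higher number from compound 1 to compound 3 (0.49 log units; beyond the scatter) and so the choice between these two groups changes the read-out. Compound 2, with hydrogen there, has no number, so the steps to it cannot be read. Nothing available explains the step.

The compounds shown leave open where hydrogen stands relative to cyano and carbamoyl. They also leave open how an amine or a carboxylic acid at this position would read.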